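This account rests on a few compounds, and the source may have more. Where it says the series, first, only, none or still open, it means among the compounds named here.

In an ADME assay on Daudi cells (Homo sapiens) for cytotoxicity, read by MTT assay (on this read-out lower numbers stand for higher toxicity in this test and higher numbers for lower toxicity in this test), compound 1 `Clc1ccc(C(Nc2ccnc3cc(Cl)ccc23)c2ccc(CN3CCCC3)cc2)cc1` gives 8.6 uM. Going by the values given here, only one other number stands beside it: compound 3 `FC(F)(F)c1ccc2c(NC(c3ccc(Cl)cc3)c3ccc(CN4CCCC4)cc3)ccnc2c1` gives 14.1 uM. The two lie within the scatter of each other, so compound 1 cannot be set apart from its neighbour. A further relative, compound 2 `COc1ccc2nccc(NC(c3ccc(Cl)cc3)c3ccc(CN4CCCC4)cc3)c2c1`, is reported as "not determined" (no result reported) and adds no number. The unmeasured compound 4 `Clc1cccc(C(Nc2ccnc3cc(Cl)ccc23)c2ccc(CN3CCCC3)cc2)c1` keeps the core of compound 1 and changes one group: 3-chlorophenyl in place of 4-chlorophenyl on a saturated chain carbon bound to an aromatic carbon and a nitrogen on an aromatic ring. In words, 3-chlorophenyl stands in place of 4-chlorophenyl on a saturated chain carbon bound to an aromatic carbon and a nitrogen on an aromatic ring. Among the compounds with values here, only one measured step exists, a 1.6-fold higher number from compound 1 to compound 3 (0.21 log units; within the scatter). It puts trifluoromethyl in place of chloro on an aromatic carbon, at a different place in the molecule, so it bears on the new change only indirectly. Even so, it is the sole guide to how far a single substitution has moved the number here, and it stayed within the scatter. No step beyond the scatter is therefore expected in this assay, and the data offer no direction. The estimated step is a 1.2-fold higher number from compound 1 to compound 4 (0.07 log units; within the scatter). For compound 4 the expected value is 10 uM, with an estimated range from 5 uM to 20 uM.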

Compound 4, half-maximal toxic concentration: 34.6 uM
The estimate for compound 4 lay 3.5-fold (0.54 log units) below the measured number, and the stated range ends below it.
By their numbers in this assay, from the lowest: compounds 1 and 3 (each within the scatter of the next); then compound 4.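

In this assay, going by these compounds alone, the swap of 4-chlorophenyl for 3-chlorophenyl on the saturated chain carbon bound to an aromatic carbon and a nitrogen on an aromatic ring gives a 4.0-fold higher number from compound 1 to compound 4 (0.60 log units; beyond the scatter) and is the first step here to lie beyond the scatter. The two compounds have the same atoms, and the leaving and entering groups match in every count, so the number depends at this position on how the chlorophenyl group is arranged, which the earlier step at another place, a 1.6-fold higher number from compound 1 to compound 3 (0.21 log units; within the scatter) and within the scatter, could not show. Nothing at hand explains why this rearrangement moves the number.

From the compounds shown here alone, with a single step at this position, it remains open whether the change would carry over to the trifluoromethyl compound 3 or to the methoxy compound 2, which has no reported result. Going by these compounds, it is equally open how a plain phenyl, a fluorophenyl or a methoxyphenyl at the same place would read in this assay and whether any of them would follow compound 4 or stay with compound 1.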